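Bromo for Trifluoromethyl: Expected Clearance of Compound 4

This account rests on a few compounds, and the source may have more. Where it says the series, first, only, none or still open, it means among the compounds named here.

Compound 1 `Fc1cc(Cl)ccc1-c1ccc(Cn2nnc3c(C(F)(F)F)cccc32)cn1` and compound 2 `Fc1cc(Cl)ccc1-c1ccc(Cn2nnc3c(Br)cccc32)cn1` share one core. In an ADME assay on microsomes from liver (Rattus norvegicus, strain Wistar) for metabolic stability, tested at 2.5 uM (on this read-out higher numbers stand for fast clearance and lower numbers for slow clearance), compound 1 gives 0.2 mL/min/g, while compound 2 gives 0.4 mL/min/g. The change between them is bromo in place of trifluoromethyl on an aromatic carbon, and it produced a 2.0-fold higher number from compound 1 to compound 2 (0.30 log units; within the scatter). Compound 3 `FC(F)(F)c1cc(Br)c2nnn(CC3CC3)c2c1` is built on another core; the difference between the two cores is not broken down here. In this assay compound 3 gives 0.2 mL/min/g. Compound 4 `Brc1cc(Br)c2nnn(CC3CC3)c2c1` is not yet measured. Among the compounds with values here, it differs from compound 3 by bromo in place of trifluoromethyl on an aromatic carbon, the same kind of change as the one between compound 1 and compound 2, though the surroundings differ: here the place is meta to a bromo group, meta to a fused ring and para to a fused ring, whereas earlier it was ortho to a fused ring and meta to a fused ring. Compound 4 is therefore expected to show a 2.0-fold higher number from compound 3 to compound 4 (0.30 log units; within the scatter), resting on the step of a 2.0-fold higher number from compound 1 to compound 2 (0.30 log units; within the scatter). The estimate for compound 4 in this assay is 0.4 mL/min/g, expected to fall between 0.2 mL/min/g and 0.8 mL/min/g.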

Compound 4, intrinsic clearance in a liver preparation (reported as CLH), per the amount of preparation that the assay uses: 2.3 mL/min/g
Estimate against measurement, compound 4: 5.8-fold (0.76 log units) below; measured number outside the range, above it.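

In this assay, bromo in place of trifluoromethyl gave a 12-fold higher number from compound 3 to compound 4 (1.06 log units; beyond the scatter), so the size of the step did not carry over from the core of compound 1 to the core of compound 3. The two steps differ: the same change on two cores in this assay, a 2.0-fold higher number (0.30 log units; within the scatter) from compound 1 to compound 2 and a 12-fold higher number (1.06 log units; beyond the scatter) from compound 3 to compound 4, 5.8-fold (0.76 log units) apart, beyond the scatter of two such steps. With a single pair on each core, this shows that the step seen on one core did not predict the step on the other, but it does not show which difference between the cores or surroundings accounts for the gap, or how the change would behave on a further core.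

The compounds shown leave open whether a nitrile or a methyl in the same place would give a number close to that of compound 3 or compound 4. They also leave open whether the step would stay as large on a core carrying an amine.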